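Halogen swap on the aryl group of the shared core

This account rests on a few compounds, and the source may have more. Where it says the series, first, only, none or still open, it means among the compounds named here.

Measured in a functional assay on the whole organism (Tail) with Rattus norvegicus as the target, in the tail flick test, with a stated time of 60 min, at a dose of 25 mg/kg by the oral route; a higher number here means more inhibition at the dose given (going by the name of the read-out), a lower number less inhibition:
compound 1 `CC(=O)N1N=C(c2ccc(F)cc2)CC1c1cn(-c2ccccc2)nc1-c1ccc(F)cc1` gives 43%
compound 2 `COc1ccc(-c2nn(-c3ccccc3)cc2C2CC(c3ccc(F)cc3)=NN2C(C)=O)cc1` gives 66%
compound 3 `Fc1ccc(C2=NN(c3ccccc3)C(c3cn(-c4ccccc4)nc3-c3ccc(F)cc3)C2)cc1` gives 41%

Compound 3 sits together with compound 1 in this assay, a number 2 percentage points lower from compound 1 to compound 3 (within the scatter), while the two values shown place compound 2 clearly above compound 3. Compound 4 `Fc1ccc(C2=NN(c3ccccc3)C(c3cn(-c4ccccc4)nc3-c3ccc(Br)cc3)C2)cc1` differs from compound 3 in one place: bromo in place of fluoro on an aromatic carbon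

Going by the values given here, no measured step exchanges fluoro for bromo. Among the compounds with values here, the one step at the same aromatic carbon, a number 23 percentage points higher from compound 1 to compound 2 (beyond the scatter), put methoxy there instead and came with a modest rise; the other step, a number 2 percentage points lower from compound 1 to compound 3 (within the scatter), concerned the amine nitrogen in a ring and stayed within the scatter. Bromo is not methoxy, so that rise is only a weak guide. The expected step of a number 5 percentage points higher from compound 3 to compound 4 (within the scatter) is small and may lie within the scatter. Compound 4 is therefore estimated at 46% in this assay, with a range from 28% to 64%.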

Compound 4, a percentage reported as inhibition, in the whole organism at one dose (the size of the read-out at that dose, not a potency): 71%
Compound 4: the middle estimate sits 25 percentage points below what was measured, outside the stated range (above it).
By their numbers in this assay, from the lowest: compounds 3 and 1 (each within the scatter of the next); then compounds 2 and 4 (each within the scatter of the next).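

In this assay, the change from 4-fluorophenyl to 4-bromophenyl gives a rise beyond the scatter, a number 30 percentage points higher from compound 3 to compound 4 (beyond the scatter), so this aromatic carbon responds on the phenyl-bearing core as well. Until now, the only change shown here was methoxy for fluoro on the acetyl-bearing core, a number 23 percentage points higher from compound 1 to compound 2 (beyond the scatter); both replacements of fluoro now raise the number, and neither goes against this. No measured evidence here accounts for the rise.

As far as these compounds go, whether bromo gives a similar rise on the core of compound 1 remains open. So does how an amine or a carboxylic acid at this carbon would read.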